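The source may report more compounds than this note shows. Statements on the series, on what has been measured and on what is new or still open speak of the compounds shown alone.

Compound 1 `O=C1N(CCCCCCCOc2ccc(Br)cc2)CCN1c1ccncc1` and compound 2 `O=C1N(CCCCCCOc2cccc(Br)c2)CCN1c1ccncc1` share one core and differ in a single place on the chain. In a functional assay on cells (Homo sapiens) for cytotoxicity (a higher number here means that more compound is tolerated, a lower number that less compound is tolerated), compound 1 gives only a limit of the assay, > 25000 nM. In this assay compound 2 likewise gives only a limit, > 25000 nM. The step between them, a step that the two limits leave unreadable from compound 1 to compound 2, thus has no readable size, and compound 2 stands where both shown values sit, at the limit of > 25000 nM in this assay, at which 2 of the 2 values shown sit. Compound 3 `O=C1N(CCCCCCOc2c(Cl)cccc2Cl)CCN1c1ccncc1` differs from compound 2 by 2,6-dichlorophenyl in place of 3-bromophenyl on an oxygen on a saturated carbon. Among the compounds with values here, the only measured step bears on a different part of the molecule and gives no size, so there is no basis for expecting a change beyond the scatter in this assay. The expected step is therefore a step that the limit leaves unreadable from compound 2 to compound 3, with a limit the most likely outcome. Compound 3 is expected to give about 40000 nM, between 20000 nM and 100000 nM.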

Compound 3, half-maximal cytotoxic concentration: > 25000 nM
Compound 3: no number, only a limit; the forecaster's own chance of this, stated with the estimate: 85%; the middle value does not contradict the limit.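

Compound 3, like compound 1 and compound 2, gives only a limit in this assay, so no step among these three compounds can be read: the limit of > 25000 nM in this assay, at which 3 of the 3 values shown sit.

The compounds shown leave open whether changing the chain or the halogens on the phenyl group alters the half-maximal cytotoxic concentration at all.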